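A few compounds are considered here, and "the series" means these few. Any claim that something is new, unique, unknown or untested is made for them only; others in the source may bear on it.

Measured so far in a functional assay on NCI-H1581 cells (Homo sapiens) for antiproliferative activity, read by CCK-8 assay, with a stated time of 72 h; a higher number here means a weaker inhibitor, a lower number a stronger inhibitor:
- compound 1 `COc1cc(OC)c(Cl)c(-c2ccc3c(NC(=O)c4ccc(N5CCN(C(C)C)CC5)cc4)n[nH]c3n2)c1Cl`: 1.4 nM
- compound 2 `COc1cc(OC)c(Cl)c(-c2ccc3c(NC(=O)c4ccc(N5CCN(C)CC5)c(Cl)c4)n[nH]c3n2)c1Cl`: 191 nM

Of these two numbers, compound 1 at 1.4 nM has the lowest, compound 2 stands at 191 nM, and the gap lies well beyond the usual scatter. The two compounds differ in more than one place, so that gap cannot be pinned on any single change. Within the data shown here, it shows only that compounds of this kind can fall far apart in this assay.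

The next compound is compound 3 `COc1cc(OC)c(Cl)c(-c2ccc3c(NC(=O)c4ccc(N(C)C)cc4)n[nH]c3n2)c1Cl`, which keeps the core of compound 1. It carries dimethylamino in place of 4-isopropylpiperazin-1-yl on an aromatic carbon, para to a large group (dimethylamino in place of 4-isopropylpiperazin-1-yl on an aromatic carbon). Among the measured compounds shown here, the ring is lost entirely, so this is a large edit, and no measured pair here tests it directly. A higher number, meaning a weaker inhibitor, is therefore expected, though with wide uncertainty. The expected size is an estimated step of an 18-fold higher number from compound 1 to compound 3 (1.25 log units; beyond the scatter), clearly beyond the scatter. For compound 3 the estimated value is 25 nM, with an expected range from 4 nM to 150 nM.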

Compound 3, half-maximal inhibitory concentration: 294 nM
The estimate for compound 3 lay 12-fold (1.07 log units) below the measured number, outside the stated range (above it).
By their numbers in this assay, from the lowest: compound 1; then compounds 2 and 3 (each within the scatter of the next).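

In this assay, putting dimethylamino in place of 4-isopropylpiperazin-1-yl on this aromatic carbon gives a 210-fold higher number from compound 1 to compound 3 (2.32 log units; beyond the scatter), a step that, unlike the gap between the earlier pair, belongs to one place on the molecule. The position, para to a large group, therefore matters a great deal in this series: with the shared core and the amide unchanged, swapping the group of 9 heavy atoms and one ring for a group of 3 heavy atoms and no ring removes most of the activity of compound 1. Nothing measured on these compounds explains why the step is this large.

On these data alone, what stays open is which part of the departing group carries the difference, since the ring, its second nitrogen and the isopropyl group all leave together, and compound 2 cannot help, as it differs from both other compounds in more than one place. A morpholine ring, which holds a six-membered ring with oxygen in place of the far nitrogen, or an unsubstituted piperazine at this same carbon, would begin to pull those parts apart.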